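Small Halogen Swaps on an Aniline Ring

This account rests on a few compounds, and the source may have more. Where it says the series, first, only, none or still open, it means among the compounds named here.

compound 1 `Brc1ccc(NCc2cn(-c3ccccc3)nc2-c2ccc(Br)cc2)cc1` gives 5000 nM
compound 2 `Cc1ccc(-c2nn(-c3ccccc3)cc2CNc2ccc(Cl)cc2)cc1` gives 6020 nM
compound 3 `Fc1ccc(NCc2cn(-c3ccccc3)nc2-c2ccc(Br)cc2)cc1` gives 3960 nM

All three numbers come from a functional assay on MCF7 cells (Homo sapiens) for antiproliferative activity, read by MTT assay, with a stated time of 48 h (on this read-out higher numbers stand for weaker inhibition and lower numbers for stronger inhibition), and sit close together. Compound 3 gives 3960 nM there, within the usual scatter of both compound 1 and compound 2, so no order among them can be claimed.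

The unmeasured compound 4 `Clc1ccc(NCc2cn(-c3ccccc3)nc2-c2ccc(Br)cc2)cc1` differs from compound 3 in one place: chloro in place of fluoro on an aromatic carbon on an aromatic carbon of a six-membered aromatic ring of carbon only, para to a large group, so that 4-fluorophenyl becomes 4-chlorophenyl. The closest measured step is fluoro in place of bromo in that same place (a 1.3-fold lower number from compound 1 to compound 3 (0.10 log units; within the scatter)) and it stays within the scatter. Compound 2 also carries the 4-chlorophenyl group and, though it differs elsewhere, shows 6020 nM in the same range.

In this assay no step beyond the scatter is therefore expected, and the estimated change is a 1.1-fold higher number from compound 3 to compound 4 (0.06 log units; within the scatter) at most a small one. For compound 4 the estimated value is 4500 nM with an expected range of 2500 nM to 8000 nM in this assay.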

Compound 4, half-maximal inhibitory concentration: 4150 nM
The estimate for compound 4 lay 1.1-fold (0.04 log units) above the measured number, within the range that was stated.
By their numbers in this assay, from the lowest: compounds 3, 4, 1 and 2 (each within the scatter of the next).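

In this assay, chloro in place of fluoro on this aromatic carbon, para to a large group, stays within the scatter (a 1.0-fold higher number from compound 3 to compound 4 (0.02 log units; within the scatter)), and so does chloro in place of bromo (a 1.2-fold lower number from compound 1 to compound 4 (0.08 log units; within the scatter)), so fluoro, chloro and bromo at this place now give numbers that cannot be told apart, where before only fluoro and bromo could be compared. Bromo in place of methyl, a swap at another place, also stays within the scatter (a 1.5-fold lower number from compound 2 to compound 4 (0.16 log units; within the scatter)), so neither place has yet shown a step beyond it. No measurement at hand explains why these numbers sit so close together.

From the compounds shown here alone, only halogens have been compared at this place, so it remains open whether an amine or a carboxylic acid there would give a step beyond the scatter. The same question stands for a longer chain.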